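Halogen exchange from compound 2 to compound 3

The compounds below may be only part of what the source reports. "The series", "measured", "known", "first", "only" and "open" are said of these compounds alone.

Measured so far in an ADME assay on microsomes from liver (Rattus norvegicus) for metabolic stability (on this read-out higher numbers stand for a longer-lived compound and lower numbers for a shorter-lived compound), for two compounds:
Compound 1 `Nc1nc(NCCNc2ncc(-c3ncc[nH]3)c(-c3ccc(F)cc3F)n2)ccc1[N+](=O)[O-]` gives > 0.5 h as a limit
Compound 2 `Nc1nc(NCCNc2ncc(-c3ncc[nH]3)c(-c3ccc(Br)cc3F)n2)ccc1[N+](=O)[O-]` gives > 0.5 h as a limit

Compound 2 has no number in this assay and stands only at the limit > 0.5 h on this read-out. Compound 3 `Nc1nc(NCCNc2ncc(-c3ncc[nH]3)c(-c3cc(F)c(Cl)cc3F)n2)ccc1[N+](=O)[O-]` has not been measured yet. It carries 4-chloro-2,5-difluorophenyl in place of 4-bromo-2-fluorophenyl on an aromatic carbon, and the counted change is 4-chloro-2,5-difluorophenyl in place of 4-bromo-2-fluorophenyl on an aromatic carbon with the rest of the structure kept.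

Among the compounds with values here, one measured step bears on this change, since it also swaps one halogen for another on an aromatic carbon. That step, a step that the two limits leave unreadable from compound 1 to compound 2, offers no size and no direction. All the data hold is the limit of > 0.5 h in this assay, at which 2 of the 2 values shown sit, for the two compounds. No step beyond the usual scatter is therefore expected in this assay, and compound 3 may well report a limit too. The expected change is a step that the limit leaves unreadable from compound 2 to compound 3 in this estimate. For compound 3 the estimated half-life is 0.7 h with an expected range from 0.3 h to 1.5 h in this assay.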

Compound 3, half-life: > 0.5 h
Compound 3: only a limit was reported; the forecaster's own chance of this, stated with the estimate: 70%; the middle value is on the limit's open side.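

In this assay compound 3 gives > 0.5 h, which is a limit and not a number. Neither the step from compound 2 to compound 3 nor the step from compound 1 to compound 3 can be read, in size or in direction. The compounds shown leave open how long the half-lives of compound 1, compound 2 and compound 3 actually are, and whether they differ at all: the limit of > 0.5 h in this assay, at which 3 of the 3 values shown sit.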